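A few compounds are considered here, and "the series" means these few. Any claim that something is new, unique, unknown or untested is made for them only; others in the source may bear on it.

Measured so far in a functional assay on A549 cells (Homo sapiens) for antiproliferative activity, read by MTT assay, with a stated time of 72 h; a higher number here means a weaker inhibitor, a lower number a stronger inhibitor:
- compound 1 `CCN1CCN(C(=O)c2cccn2-c2ccc(Nc3ncc(Cl)c(Nc4ccccc4NS(C)(=O)=O)n3)c(OC)c2)CC1` gives > 10000 nM, which is a limit of the assay and not a number.
- compound 2 `COc1cc(-n2cccc2C(=O)NCCO)ccc1Nc1ncc(Cl)c(Nc2ccccc2NS(C)(=O)=O)n1` gives > 10000 nM, again a limit of the assay and not a number.
- compound 3 `CCN(CC)C(=O)c1cccn1-c1ccc(Nc2ncc(Cl)c(Nc3ccccc3NS(C)(=O)=O)n2)c(OC)c1` gives 970 nM.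

Among the measured compounds shown here, compound 3 thus holds the only number in this assay; the two other values sit at the limit (the limit of > 10000 nM in this assay, at which 2 of the 3 values shown sit). Both steps leading to it, an at least 10-fold lower number from compound 1 to compound 3 (1.01 log units; beyond the scatter) and an at least 10-fold lower number from compound 2 to compound 3 (1.01 log units; beyond the scatter), are large and beyond the scatter, while a step that the two limits leave unreadable from compound 1 to compound 2 is unreadable between two limits.

Compound 4 `COc1cc(-n2cccc2C(=O)N2CC(O)C2)ccc1Nc1ncc(Cl)c(Nc2ccccc2NS(C)(=O)=O)n1` differs from compound 3 in one place: 3-hydroxyazetidin-1-yl in place of diethylamino on a carbonyl carbon. The change brings in a ring, as in compound 1, and a hydroxyl donor, as in compound 2; both of those compounds sit at the limit, and only the diethylamino of compound 3 yields a number. The two measured steps therefore point the same way, toward a higher number for compound 4, of a size comparable to those steps, with a fair chance that the assay again reports only a limit.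

For compound 4 the expected step is a 6.2-fold higher number from compound 3 to compound 4 (0.79 log units; beyond the scatter). The estimate for compound 4 in this assay is 6000 nM, within 1500 nM to 25000 nM.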

Compound 4, half-maximal inhibitory concentration: 2080 nM
Compound 4: the middle estimate sits 2.9-fold (0.46 log units) above what was measured; low and high end bracket the measured number.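

In this assay, the position on the carbonyl carbon accepts a ring and a hydroxyl donor together, and 3-hydroxyazetidin-1-yl in place of diethylamino gives a 2.1-fold higher number from compound 3 to compound 4 (0.33 log units; beyond the scatter). Compound 4 is the second compound here with a number, so neither a ring nor a hydroxyl on this amide by itself puts a compound at the limit: 3-hydroxyazetidin-1-yl gives an at least 4.8-fold lower number from compound 2 to compound 4 (0.68 log units; beyond the scatter) against (2-hydroxyethyl)amino, and an at least 4.8-fold lower number from compound 1 to compound 4 (0.68 log units; beyond the scatter) against 4-ethylpiperazin-1-yl. Both of these steps are bounds and not measured sizes, and the step between compound 1 and compound 2 cannot be read: the limit of > 10000 nM in this assay, at which 2 of the 4 values shown sit.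

Still open, as far as these compounds go, is whether the four-membered ring or its hydroxyl separates compound 4 from compound 1 and compound 2, a question that an unsubstituted azetidin-1-yl or a 3-methoxyazetidin-1-yl on the same carbonyl carbon would address. Also open, from the compounds shown here alone, is how a larger ring without a second nitrogen, such as pyrrolidin-1-yl or piperidin-1-yl, or a longer dialkylamino chain than diethylamino, would read in this assay.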